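Lengthening the tetrazole chain by one carbon

This account rests on a few compounds, and the source may have more. Where it says the series, first, only, none or still open, it means among the compounds named here.

Measured so far:
compound 1 `CCCc1c(OCCCCC(=O)O)ccc(C(C)=O)c1O`: 5.8
compound 2 `CCCc1c(OCCCCCC(=O)O)ccc(C(C)=O)c1O`: 6
compound 3 `CCCc1c(OCCCCCCc2nn[nH]n2)ccc(C(C)=O)c1O`: 7.1

In a functional assay on ileum (Cavia porcellus) for inhibition of cysteinyl leukotriene receptor (Homo sapiens) (a higher number here means a more potent compound, by a factor of ten per unit of this negative logarithm, a lower number a less potent compound), compound 3 stands highest of the three; the steps of a number 1.30 log units higher from compound 1 to compound 3 (beyond the scatter) and a number 1.10 log units higher from compound 2 to compound 3 (beyond the scatter) both lie beyond the scatter. Compound 4 `CCCc1c(OCCCCCCCc2nn[nH]n2)ccc(C(C)=O)c1O` keeps the shared core and changes only the chain: (2H-tetrazol-5-yl)methyl in place of 2H-tetrazol-5-yl on a saturated chain carbon, six bonds along the chain from an oxygen on an aromatic ring. Going by the values given here, the one measured step that bears on such a lengthening is a number 0.20 log units higher from compound 1 to compound 2 (within the scatter), where a chain one carbon longer left the number within the scatter. No chain lengthening with a tetrazole end has been measured. The step of a number 0.10 log units higher from compound 3 to compound 4 (within the scatter) is therefore expected to stay small, without a clear direction. Compound 4 is estimated at 7.2, with a range from 6.6 to 7.8.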

Compound 4, negative logarithm of the antagonist equilibrium constant: 7
For compound 4 the middle estimate is 0.20 log units above the measured one; the measured number falls inside the stated range.
By their numbers in this assay, from the lowest: compounds 1 and 2 (each within the scatter of the next); then compounds 4 and 3 (each within the scatter of the next).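

Adding one carbon to the tetrazole chain, at the place six bonds along from an oxygen on an aromatic ring, leaves the number level (a number 0.10 log units lower from compound 3 to compound 4 (within the scatter)). The longer chain still keeps its tetrazole end well clear of the shorter carboxy compounds (a number 1.00 log units higher from compound 2 to compound 4 (beyond the scatter); a number 1.20 log units higher from compound 1 to compound 4 (beyond the scatter)). Replacing carboxy with 2-(2H-tetrazol-5-yl)ethyl also gives a similar gain on a second chain length: the same change on two cores in this assay, a number 1.30 log units higher (beyond the scatter) from compound 1 to compound 3 and a number 1.00 log units higher (beyond the scatter) from compound 2 to compound 4, 0.30 log units apart, within the scatter of two such steps.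

On these data alone, how a carboxylic acid on the chain of compound 4 would compare remains open. So does whether a still longer chain would hold the number.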